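The source may hold more compounds than are shown below. What is called first, only, known or untested is meant among the compounds shown, and "the series" means these compounds.

Measured so far:
compound 1, `c1ccc(CCc2ccccc2CSC2=NCCS2)cc1`: 0%
compound 2, `Clc1ccc2[nH]c(SCc3ccccc3/C=C\c3ccccc3)nc2c1`: 49%
compound 3, `c1ccc(CCc2ccccc2CSc2nc3ccccc3[nH]2)cc1`: 43%

In an assay on isolated protein for inhibition of Indoleamine 2,3-dioxygenase 1 (Homo sapiens), with a stated time of 60 min, tested at 10 uM (on this read-out higher numbers stand for more inhibition at the one concentration tested (going by the name of the read-out) and lower numbers for less inhibition), compound 1 gives 0%, compound 2 gives 49% and compound 3 gives 43%. Compound 2 carries the largest of the three figures, but its gap to compound 3 lies within the scatter, so the two cannot be told apart on these numbers; only the gap from compound 2 down to compound 1 is beyond the scatter. Among the compounds with values here, no pair among the three differs in just one place, so no single step has been measured.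

Compound 4, `Clc1ccc2[nH]c(SCc3ccccc3SCc3ccccc3)nc2c1`, is not yet measured. It departs from compound 2 as follows: benzylsulfanyl in place of 2-phenylethenyl on an aromatic carbon. Within the data shown here, with no measured step of this kind to lean on, the expectation for this assay is no change beyond the scatter in either direction, since compound 2 at 49% and compound 3 at 43% both sit in the same middle region despite their differences. Compound 4 is therefore estimated at 42%, within 18% to 66%, an expected step of a number 7 percentage points lower from compound 2 to compound 4 (within the scatter).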

Compound 4, a percentage reported as inhibition, at one concentration (the size of the read-out at that concentration, not a potency): 19%
Compound 4: the middle estimate sits 23 percentage points above what was measured, within the range that was stated.
By their numbers in this assay, from the lowest: compound 1; then compound 4; then compounds 3 and 2 (each within the scatter of the next).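

Benzylsulfanyl in place of 2-phenylethenyl, on an aromatic carbon of a six-membered aromatic ring of carbon only and ortho to a large group, gives a number 30 percentage points lower from compound 2 to compound 4 (beyond the scatter) in this assay and is the first single change read in this series. The two groups have the same count of heavy atoms and each carries one six-membered aromatic ring of carbon only, so this place is not indifferent to which of the two groups it bears. No measured evidence bears on the reason for this step.

This one step cannot separate the entry of sulfur from the loss of the double bond outside aromatic rings. Also open, on these data alone, is how this place responds to an amine, a carboxylic acid or a longer chain ending in the same ring.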